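Nitro to methoxy on the shared core

This account rests on a few compounds, and the source may have more. Where it says the series, first, only, none or still open, it means among the compounds named here.

Among the compounds with values here, compound 2 `CO/C(O)=C1\C(C)=NC(C)=C(C(=O)OCC(C)C)C1c1cccc([N+](=O)[O-])c1` gives 0.59 nM in a functional assay (muscle tissue) for inhibition, with Cavia porcellus as the target (on this read-out lower numbers stand for stronger inhibition and higher numbers for weaker inhibition), and stands as the higher of the two numbers measured so far; compound 1 `CO/C(O)=C1\C(C)=NC(C)=C(C(=O)OCC(C)C)C1c1cccc(C#N)c1` gives 0.27 nM. Within the data shown here, the only measured step, a 2.2-fold higher number from compound 1 to compound 2 (0.34 log units; beyond the scatter), exchanges one substituent on the same aromatic carbon and is modest. Compound 3 `CO/C(O)=C1\C(C)=NC(C)=C(C(=O)OCC(C)C)C1c1cccc(OC)c1` carries the change (methoxy in place of nitro on an aromatic carbon). Among the measured compounds shown here, no measured pair covers a methoxy group at that place, so that single step sets only the scale expected for such an exchange. A modest rise in the number is expected for compound 3, estimated at 1.5 nM within 0.4 nM to 6 nM, the expected step being a 2.5-fold higher number from compound 2 to compound 3 (0.41 log units; beyond the scatter).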

Compound 3, half-maximal inhibitory concentration: 7.1 nM
Compound 3: the middle estimate sits 4.7-fold (0.68 log units) below what was measured; measured number above the stated range.
By their numbers in this assay, from the lowest: compound 1; then compound 2; then compound 3.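

Methoxy on this aromatic carbon costs far more than the nitrile-to-nitro exchange suggested: methoxy in place of nitro gives a 12-fold higher number from compound 2 to compound 3 (1.08 log units; beyond the scatter) in this assay, and methoxy in place of nitrile gives a 26-fold higher number from compound 1 to compound 3 (1.42 log units; beyond the scatter). Both steps are large, whereas the earlier exchange was only modest, so the choice of group at this place can shift the number strongly. No measurement at hand accounts for the size of these steps. Still open, on these data alone, is whether an amine, a carboxylic acid or a fluorine at this carbon would lie nearer compound 1 or compound 3. Also open, as far as these compounds go, is whether the same order holds with a longer ester chain on the shared core.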